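Swapping a bromophenyl arm for pyridinyl in a protease inhibitor

The source may report more compounds than this note shows. Statements on the series, on what has been measured and on what is new or still open speak of the compounds shown alone.

Measured compounds:
- compound 1, `O=C(O)c1ccc(NC(c2ccc(Br)cc2)c2ccc3cccnc3c2O)cc1`: 6700 nM
- compound 2, `O=[N+]([O-])c1ccc(NC(c2ccc(Br)cc2)c2ccc3cccnc3c2O)cc1`: "not determined" (no result reported)

Within the data shown here, compound 1 is the only compound here with a number in an assay on isolated protein for inhibition of CAAX prenyl protease 2 (Homo sapiens), with stated times of 60 s and 60 min; on this read-out lower numbers stand for stronger inhibition and higher numbers for weaker inhibition. Compound 2 shares the same core but carries a nitro group where compound 1 has a carboxylic acid; for compound 2 this assay gave no result, so nothing can be drawn from it. Compound 1 therefore stands alone, and its value is the only anchor.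

Compound 3, `O=C(O)c1ccc(NC(c2cccnc2)c2ccc3cccnc3c2O)cc1`, is built from compound 1 by one change: pyridin-3-yl in place of 4-bromophenyl on a saturated chain carbon bound to an aromatic carbon and a nitrogen on an aromatic ring. Among the measured compounds shown here, no measured pair in this set shows what such a change does, so the expectation rests on compound 1 alone. The change removes a ring of carbon only and puts in a ring with one nitrogen, which adds one hydrogen-bond acceptor.

For compound 3 a modest loss of potency is expected, a step from compound 1 to compound 3 of about a 2.2-fold higher number from compound 1 to compound 3 (0.35 log units; beyond the scatter), which is beyond the usual scatter but not large. Compound 3 is therefore estimated at 15000 nM, with a plausible range from 4000 nM to 50000 nM.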

Compound 3, half-maximal inhibitory concentration: 14000 nM
Beside the measured number, compound 3's estimate is 1.1-fold (0.03 log units) above it; the measured number falls inside the stated range.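

In this assay the exchange of 4-bromophenyl for pyridin-3-yl gives a 2.1-fold higher number from compound 1 to compound 3 (0.32 log units; beyond the scatter) at this saturated chain carbon, the first measured step at this position in the compounds shown. The step is modest but lies beyond the usual scatter, so this place in the molecule does respond to a change of ring, while the bromine-free compound with a ring nitrogen still gives a measurable half-maximal inhibitory concentration. Among these compounds, nothing measured here explains the rise, and the single step cannot be divided between the bromine that leaves and the ring nitrogen that enters.

A plain phenyl ring at this place would separate those two parts of the change, and pyridin-2-yl or pyridin-4-yl would show whether the place of the nitrogen within the ring matters. Going by these compounds, compound 2 has no reported result, so whether the carboxylic acid shared by compound 1 and compound 3 matters for inhibition also stays open.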